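A few compounds are considered here, and "the series" means these few. Any claim that something is new, unique, unknown or untested is made for them only; others in the source may bear on it.

Within the data shown here, compound 1 `C=C1CC[C@H]2C(C)(C)CCC[C@]2(C)[C@H]1CC/C(C)=C/Cc1c(O)cc(O)c2c(=O)c(O)c(-c3ccc(O)cc3)oc12` is the only member of the series with a numbered read-out in a functional assay on A549 cells (Homo sapiens) for cytotoxicity, read by XTT assay, with a stated time of 72 h; on this read-out lower numbers stand for stronger inhibition and higher numbers for weaker inhibition: compound 1 gives 32000 nM. Compound 3 `C=C1CC[C@H]2C(C)(C)CCC[C@]2(C)[C@H]1CC/C(C)=C/COc1cc(O)c2c(=O)c(O)c(-c3ccc(O)cc3)oc2c1` carries the same atoms joined differently; the difference between the two cores is not broken down here. In this assay compound 3 returns only the limit of the assay, > 100000 nM. Compound 2 `C=C1CC[C@H]2C(C)(C)CCC[C@]2(C)[C@H]1CC/C(C)=C/COc1cc(O)c2c(=O)c(O)c(-c3ccc(OC)cc3)oc2c1` differs from compound 3 by methyl in place of hydrogen on an oxygen on an aromatic ring. In this assay compound 2 likewise returns only a limit, > 100000 nM. The step that the two limits leave unreadable from compound 3 to compound 2 therefore cannot be sized, because both ends sit at the limit of > 100000 nM in this assay, at which 2 of the 3 values shown sit. Compound 4 `C=C1CC[C@H]2C(C)(C)CCC[C@]2(C)[C@H]1CC/C(C)=C/Cc1c(O)cc(O)c2c(=O)c(O)c(-c3ccc(OC)cc3)oc12` is still to be measured; it differs from compound 1 by methyl in place of hydrogen on an oxygen on an aromatic ring, the same change as that made between compound 3 and compound 2. Since that pair gives no readable step, the expectation rests on compound 1 alone, with its value 32000 nM. The step of a 1.3-fold higher number from compound 1 to compound 4 (0.10 log units; within the scatter) is accordingly expected to be small, in either direction, with a fair chance of a limit instead of a number. In this assay compound 4 is expected near 40000 nM, between 15000 nM and 150000 nM.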

Compound 4, half-maximal inhibitory concentration: > 100000 nM
Compound 4: no number, only a limit; the forecaster's own chance of this, stated with the estimate: 30%; middle value at least 2.5-fold (0.39 log units) from the limit.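

In this assay, among these compounds, the change from 4-hydroxyphenyl to 4-methoxyphenyl on the core of compound 1 gives an at least 3.1-fold higher number from compound 1 to compound 4 (0.49 log units; beyond the scatter), so on this core the hydroxy compound holds the only numbered value. From the compounds shown here alone, compound 4 returns only a limit of the assay, > 100000 nM, so the full size of this step remains unknown. The same change from compound 3 to compound 2 cannot be read, so the compounds shown neither confirm nor rule out that the step carries from one core to the other, and no two sizes can be compared: the limit of > 100000 nM in this assay, at which 3 of the 4 values shown sit.

Still open, going by these compounds, is whether an ethyl group or a longer chain on this oxygen, in place of methyl, would also end at the limit on the core of compound 1. Also open, on these data alone, is whether an amine or a carboxylic acid in place of this hydroxy would return a numbered value on that core.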